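A few compounds are considered here, and "the series" means these few. Any claim that something is new, unique, unknown or untested is made for them only; others in the source may bear on it.

Compounds measured so far:

Compound 1, `Cc1ncc(S(=O)(=O)NC(=O)NC/C=C2\CCCc3cnn(Cc4ccc(Cl)cc4Cl)c32)s1`, gives 7 nM in an assay on isolated protein for displacement of a labelled ligand from prostaglandin E2 receptor EP3 subtype (Homo sapiens), read by scintillation counting, with a stated time of 2 h; a lower number here means a stronger inhibitor, a higher number a weaker inhibitor.
Compound 2, `O=C(NC/C=C1\CCCc2cnn(Cc3ccc(Cl)cc3Cl)c21)NS(=O)(=O)c1cccs1`, gives 15 nM in this assay.

For the measured compounds named here, compound 2 has the higher of the two numbers, and its nearest neighbour is compound 1; the only measured step, a 2.1-fold higher number from compound 1 to compound 2 (0.33 log units; beyond the scatter), is the change of the group on the sulfonyl sulfur. Compound 3, `COc1ccccc1S(=O)(=O)NC(=O)NC/C=C1\CCCc2cnn(Cc3ccc(Cl)cc3Cl)c21`, has not yet been measured in this assay. It differs from compound 2 at the same place: 2-methoxyphenyl in place of thiophen-2-yl on a sulfonyl sulfur. Going by the values given here, the single step that bears on this change, from compound 1 to compound 2, shows that swapping one five-membered aromatic group for another at the sulfonyl sulfur moved the number only modestly, and nothing measured here says how a six-membered carbon-only ring with a methoxy group behaves at that position. Compound 3 is therefore expected to land close to compound 2, with the step of a 1.3-fold lower number from compound 2 to compound 3 (0.10 log units; within the scatter) possibly within the scatter and no firm direction. The estimate for compound 3 is 12 nM, between 4 nM and 40 nM.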

Compound 3, inhibition constant: 62 nM
Beside the measured number, compound 3's estimate is 5.2-fold (0.71 log units) below it; measured number outside the range, above it.
By their numbers in this assay, from the lowest: compound 1; then compound 2; then compound 3.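

The group on the sulfonyl sulfur matters more in this assay than the exchange of one five-membered aromatic group for another had indicated: 2-methoxyphenyl in place of thiophen-2-yl gives a 4.1-fold higher number from compound 2 to compound 3 (0.62 log units; beyond the scatter), and 2-methoxyphenyl in place of 2-methyl-1,3-thiazol-5-yl gives an 8.9-fold higher number from compound 1 to compound 3 (0.95 log units; beyond the scatter). Both steps lie beyond the scatter, so among these three compounds, the one with a six-membered aromatic ring of carbon only at this position has the highest number, and the position does not treat these aromatic groups as interchangeable. Nothing available accounts for this difference between the groups.

The compounds shown leave open whether the higher number goes with the six-membered ring or with the methoxy group, as the two enter together in compound 3, and an unsubstituted phenyl group would separate them. Also open, from the compounds shown here alone, is how a non-aromatic group on the sulfonyl sulfur, such as a methyl or cyclopropyl group, or a phenyl ring carrying an amine or a carboxylic acid, would read in this assay.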